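A few compounds are considered here, and "the series" means these few. Any claim that something is new, unique, unknown or untested is made for them only; others in the source may bear on it.

Compound 1 `CC(C)(C)c1ccc(NC(=O)c2ccc(OC(F)(F)C(F)F)cc2)cc1`: 70 nM
Compound 2 `O=C(Nc1ccc(I)cc1)c1ccc(OC(F)(F)F)cc1`: 280 nM
Compound 3 `CC(C)(C)c1ccc(NC(=O)c2ccc(OC(F)(F)F)cc2)cc1`: 120 nM

All three share one amide core and were tested in a functional assay on HEK293 cells for antagonist activity at transient receptor potential cation channel subfamily V member 1 (Homo sapiens), read by calcium flux; a lower number here means a stronger inhibitor, a higher number a weaker inhibitor. Compound 3 stands second highest of the three numbers: a 1.7-fold higher number from compound 1 to compound 3 (0.23 log units; within the scatter), while a 2.3-fold lower number from compound 2 to compound 3 (0.37 log units; beyond the scatter). Compound 4 `O=C(Nc1ccc(C(F)(F)F)cc1)c1ccc(OC(F)(F)F)cc1` differs from compound 3 by trifluoromethyl in place of tert-butyl on an aromatic carbon. For the measured compounds named here, no measured step covers this exact swap. Going by the values given here, the only step at this aromatic carbon, a 2.3-fold lower number from compound 2 to compound 3 (0.37 log units; beyond the scatter), was modest, so the group at this spot shifts the number by a modest amount. A modest rise, back toward compound 2, is therefore expected, and the expected change is a 2.1-fold higher number from compound 3 to compound 4 (0.32 log units; beyond the scatter). Compound 4 is expected to give 250 nM, with a range from 100 nM to 600 nM.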

Compound 4, half-maximal inhibitory concentration: 220 nM
The estimate for compound 4 lay 1.1-fold (0.06 log units) above the measured number, and the stated range covers the measured number.
By their numbers in this assay, from the lowest: compounds 1, 3, 4 and 2 (each within the scatter of the next, the first and the last beyond it).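

At this aromatic carbon in this assay, trifluoromethyl cannot be separated from tert-butyl, with a 1.8-fold higher number from compound 3 to compound 4 (0.26 log units; within the scatter) as the step, or from iodo, with a 1.3-fold lower number from compound 2 to compound 4 (0.10 log units; within the scatter) as the step. Compound 4 thus sits within the scatter of both compounds, even though the step between compound 2 and compound 3 lies beyond it. No supporting measurement is available to explain this result. Still open, from the compounds shown here alone, is how this position would respond to a quite different group, such as an amine or a carboxylic acid.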